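A few compounds are considered here, and "the series" means these few. Any claim that something is new, unique, unknown or untested is made for them only; others in the source may bear on it.

Working notes on a series tested in an assay on isolated protein for inhibition of Rho-associated protein kinase 2 (Homo sapiens), read by scintillation counting, radiometric assay and 33P incorporation, with a stated time of 40 min, in the presence of a further agent that is not named here; a higher number here means a weaker inhibitor, a lower number a stronger inhibitor. Compound 1 `CN(C)c1ccc(C(=O)Nc2cccc(NC(=O)COc3ccc4c(c3)NC(=O)CC4)c2)cc1` gives 3140 nM in this assay. Compound 2 `COc1cc(OCC(=O)Nc2cccc(NC(=O)c3ccc(N(C)C)cc3)c2)ccc1C=O` gives 306 nM. Among the measured compounds shown here, the single one-place step among the measured compounds is a 10-fold lower number from compound 1 to compound 2 (1.01 log units; beyond the scatter); it sits on an oxygen on a saturated carbon, at the far side of the shared core. Compound 3 `N#Cc1ccc(C(=O)Nc2cccc(NC(=O)COc3ccc4c(=O)ccoc4c3)c2)cc1` gives 15 nM, the lowest of the three numbers, with compound 2 the nearest and compound 1 the furthest; both gaps are beyond the scatter, so compound 3 is the strongest inhibitor of the three measured. For the measured compounds named here, compound 3 differs from compounds 1 and 2 in two places at once, so no single step is given for those pairs.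

Compound 4 `Nc1cccc(C(=O)Nc2cccc(NC(=O)COc3ccc4c(=O)ccoc4c3)c2)c1` is not yet measured. It differs from compound 3 as follows: 3-aminophenyl in place of 4-cyanophenyl on a carbonyl carbon. Going by the values given here, no measured step touches this end of the molecule: the one step available concerns the other side, and although it was large it says nothing about the change in hand. Among the compounds with values here, with no directly relevant step, no direction can be read from the data, and a result near or within the scatter is the plainest expectation, with some allowance for a weaker number. For compound 4 the estimate in this assay is 30 nM, expected to fall between 8 nM and 120 nM. The corresponding expected step is a 2.0-fold higher number from compound 3 to compound 4 (0.30 log units; within the scatter).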

Compound 4, half-maximal inhibitory concentration: 58 nM
Compound 4: middle estimate off by 1.9-fold (0.29 log units), on the low side; the range from low to high includes it.
By their numbers in this assay, from the lowest: compound 3; then compound 4; then compound 2; then compound 1.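

Among the compounds shown here, this is the first step read at the end of the molecule where the aryl group sits on a carbonyl carbon whose other neighbour is an amide-type nitrogen: in this assay, 3-aminophenyl in place of 4-cyanophenyl gives a 3.9-fold higher number from compound 3 to compound 4 (0.59 log units; beyond the scatter). The earlier data showed a change only at the far side of the shared core, where the step was a 10-fold lower number from compound 1 to compound 2 (1.01 log units; beyond the scatter); this end also moves the number, though by a smaller step, and the change here keeps a six-membered aromatic ring of carbon only while the nitrile gives way to an amine carrying a hydrogen-bond donor. Nothing measured on these compounds explains the step.

The single step changes both the substituent and its place on the ring, so the compounds shown cannot separate the contribution of either one. An unsubstituted phenyl, or a carboxylic acid or methoxy group on the same ring, would show whether the nitrile, the amine or neither matters at this position, and whether the step holds with other groups at the far side of the core.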